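A Methoxy Added to a Weak Sulfonate Ester

The source may report more compounds than this note shows. Statements on the series, on what has been measured and on what is new or still open speak of the compounds shown alone.

These three sulfonate esters share one core and differ at two places: the group on the nitrogen of the core and the substituents on the phenoxy ring. Compound 1 `CN1CCN(c2ccc(S(=O)(=O)Oc3cccc(F)c3)cc2)C1=O` gives 5800 nM in a functional assay on M21 cells (Homo sapiens) for antiproliferative activity, read by sulforhodamine B assay, with a stated time of 48 h; a higher number here means a weaker inhibitor, a lower number a stronger inhibitor. Compound 2 `COc1ccc(OS(=O)(=O)c2ccc(N3CCN(C)C3=O)cc2)cc1OC` gives 8500 nM in this assay. Compound 3 `CCCCN1CCN(c2ccc(S(=O)(=O)Oc3ccccc3)cc2)C1=O` returns only a limit, > 100000 nM, not a number. That limit, (the limit of > 100000 nM in this assay, at which 1 of the 3 values shown sits), is where compound 3 stands: at the weak edge of the set, while compounds 1 and 2 each have measured values.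

The change to compound 4 `CCCCN1CCN(c2ccc(S(=O)(=O)Oc3ccc(OC)cc3)cc2)C1=O` is methoxy in place of hydrogen on an aromatic carbon. Among the measured compounds shown here, no measured pair differs by this change alone, so its size cannot be read from the data. Compound 2 carries two methoxy groups and compound 1 a fluorine, each with a methyl on the core nitrogen; compound 3 differs from them in carrying a butyl. A single methoxy is expected to change little, an estimated step of a number no higher from compound 3 to compound 4 (the limit leaves the size open), within the scatter. Compound 4 is therefore estimated at 100000 nM, ranging from 30000 nM to 300000 nM, with a limit again the likely outcome.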

Compound 4, half-maximal inhibitory concentration: > 100000 nM
Compound 4: no number, only a limit (the forecaster's own chance of this, stated with the estimate: 70%); the middle value lies on the limit itself.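

Compound 3 and compound 4 both return only a limit in this assay, so the step between them cannot be read: the limit of > 100000 nM in this assay, at which 2 of the 4 values shown sit.

The compounds shown leave open what methoxy in place of hydrogen does to activity, and whether the butyl on the core nitrogen matters.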